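The compounds below may be only part of what the source reports. "The series", "measured", "known", "first", "only" and "open" are said of these compounds alone.

Measured in a functional assay on OVCAR-5 cells (Homo sapiens) for inhibition, read by sulforhodamine B assay, with a stated time of 48 h; on this read-out lower numbers stand for stronger inhibition of growth and higher numbers for weaker inhibition of growth:
Compound 1 `CCCCCCCCCCCC[C@@H](O)[C@H]1CC[C@H]([C@H](O)CCCCCCCCCCNC(=O)c2ccnn2C)O1`: 100000 nM
Compound 2 `CCCCCCCCCCCC[C@@H](O)[C@H]1CC[C@H]([C@H](O)CCCCCCCCCCN(C)C(=O)c2ccnn2C)O1`: 14100 nM

Of the two measured compounds, compound 2 has the lower number in this assay. Compound 3 `CCCCCCCCCCCC[C@@H](O)[C@H]1CC[C@H]([C@H](O)CCCCCCCCCCNCc2ccnn2C)O1` differs from it by ((1-methyl-1H-pyrazol-5-yl)methyl)amino in place of methyl((1-methyl-1H-pyrazol-5-yl)carbonyl)amino on a saturated chain carbon, ten or more bonds along the chain from an oxygen on a saturated carbon and a saturated ring carbon. Among the measured compounds shown here, the only measured step, a 7.1-fold lower number from compound 1 to compound 2 (0.85 log units; beyond the scatter), is methyl in place of hydrogen on an amide-type nitrogen. For the measured compounds named here, it bears only in part, since no measured step removes the carbonyl. No step beyond the scatter is therefore expected, and no direction is favoured: the expected step is a 1.2-fold lower number from compound 2 to compound 3 (0.07 log units; within the scatter). For compound 3 the estimate is 12000 nM, with an expected range from 2500 nM to 60000 nM.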

Compound 3, concentration for 50% growth inhibition: 3090 nM
Compound 3: the middle estimate sits 3.9-fold (0.59 log units) above what was measured; low and high end bracket the measured number.
By their numbers in this assay, from the lowest: compound 3; then compound 2; then compound 1.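

Removing the carbonyl helps here: with (1-methyl-1H-pyrazol-5-yl)methyl in place of (1-methyl-1H-pyrazol-5-yl)carbonyl on the amine nitrogen, this assay shows a 32-fold lower number from compound 1 to compound 3 (1.51 log units; beyond the scatter). The amine also outdoes the methylated amide, with a 4.6-fold lower number from compound 2 to compound 3 (0.66 log units; beyond the scatter), so a methyl on the amide nitrogen does not account for the whole gain available in this place. Nothing measured here explains this gain.

The compounds shown leave open how a methyl on this amine nitrogen would read, and whether a phenyl in place of the 1-methyl-1H-pyrazol-5-yl ring would keep the gain.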